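The source may hold more compounds than are shown below. What is called first, only, known or untested is meant among the compounds shown, and "the series" means these compounds.

Measured in a functional assay on HCT-8 cells (Homo sapiens) for antiproliferative activity, read by MTT assay, with a stated time of 48 h; on this read-out higher numbers stand for weaker inhibition and lower numbers for stronger inhibition:
- Compound 1 `C=C(c1ccc(OC)cc1NC(=O)CO)c1ccc(OC)c2c1OC(C)(C)C=C2`: 130 nM
- Compound 2 `COc1ccc(C(=O)c2cc(OC)c(OC)c(OC)c2)c(NC(=O)CN(C)C)c1`: 790 nM

Compound 1, at 130 nM, holds the lower of the two numbers, and compound 2 lies above it by more than the scatter. Compound 3 `C=C(c1ccc(OC)cc1NC(=O)CN)c1ccc(OC)c2c1OC(C)(C)C=C2` departs from compound 1 in one place: amino in place of hydroxy on a saturated chain carbon bound to a carbonyl carbon. Among the measured compounds shown here, no measured pair shows this change, so in this assay no step beyond the scatter is expected, with a slight lean toward higher numbers. The estimated step is a 1.4-fold higher number from compound 1 to compound 3 (0.14 log units; within the scatter). The expected value for compound 3 is 180 nM, within an estimated range of 60 nM to 550 nM.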

Compound 3, half-maximal inhibitory concentration: 190 nM
The estimate for compound 3 lay 1.1-fold (0.02 log units) below the measured number; low and high end bracket the measured number.
By their numbers in this assay, from the lowest: compounds 1 and 3 (each within the scatter of the next); then compound 2.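

In this assay, among the compounds shown here, amino in place of hydroxy on a saturated chain carbon bound to a carbonyl carbon gives (a 1.5-fold higher number from compound 1 to compound 3 (0.16 log units; within the scatter)), the first single-place comparison at this position. On the core of compound 1, this read-out therefore does not separate hydroxy from amino at this place. Nothing measured here explains that result.

Going by these compounds, whether a dimethylamino group, a carboxylic acid or a longer chain at this place would also stay within the scatter of compound 1 remains open. The compounds shown test only this one exchange at this position.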